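This account rests on a few compounds, and the source may have more. Where it says the series, first, only, none or still open, it means among the compounds named here.

Measured in a functional assay on MDA-MB-231 cells (Homo sapiens) for cytotoxicity, read by sulforhodamine B assay, with a stated time of 72 h; a higher number here means a weaker inhibitor of growth, a lower number a stronger inhibitor of growth:
compound 1 `O=C(Nc1ccccc1C(F)(F)F)C1CCc2ccccc2N1C(=O)c1cccc(Cl)c1`: 288 nM
compound 2 `COc1ccc(NC(=O)C2CCc3ccccc3N2)cc1`: 51400 nM
compound 3 `O=C(Nc1cc(C(F)(F)F)cc(C(F)(F)F)c1)C1CCc2ccccc2N1C(=O)c1ccc(Cl)cc1`: 2000 nM

Compound 1 has the lowest number of the three in this assay; compound 3 sits well beyond the scatter from it, and compound 2 lies furthest away of all. Compound 4 `O=C(Nc1ccccc1C(F)(F)F)C1CCc2ccccc2N1C(=O)c1ccccc1Cl` differs from compound 1 only on the carbonyl carbon attached to the ring nitrogen: 2-chlorophenyl in place of 3-chlorophenyl on a carbonyl carbon. Going by the values given here, no measured pair shows this same change, so its effect in this assay is unknown from the series itself; the expectation is a step of modest size, if any, with the odds leaning slightly toward a higher number. Compound 4 is therefore estimated at 400 nM, within 130 nM to 1500 nM, the step of a 1.4-fold higher number from compound 1 to compound 4 (0.14 log units; within the scatter) expected to stay within or only just beyond the scatter.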

Compound 4, concentration for 50% growth inhibition: 2530 nM
The estimate for compound 4 lay 6.3-fold (0.80 log units) below the measured number; the measured number lies above the stated range.
By their numbers in this assay, from the lowest: compound 1; then compounds 3 and 4 (each within the scatter of the next); then compound 2.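

In this assay, 2-chlorophenyl in place of 3-chlorophenyl on the carbonyl carbon gives an 8.8-fold higher number from compound 1 to compound 4 (0.94 log units; beyond the scatter). Going by these compounds alone, with the same atoms joined differently, this position is sensitive to where the chlorine stands on the ring, a point the earlier compounds could not show. No evidence on the cause of this step is at hand.

Still open, as far as these compounds go, is how 4-chlorophenyl would read with the rest of compound 1 unchanged. Also open, from the compounds shown here alone, is whether a plain phenyl or a 3-aminophenyl on this carbonyl carbon would keep the number of compound 1.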